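Removing the 3,5-dibromo-2-hydroxyphenyl group from compound 1

The source may report more compounds than this note shows. Statements on the series, on what has been measured and on what is new or still open speak of the compounds shown alone.

Compound 1 `O=C(Nc1ccc(Sc2nc3ccccc3s2)c(Cl)c1)c1cc(Br)cc(Br)c1O`: 76000 nM
Compound 2 `COc1ccccc1C(=O)Nc1ccccc1`: > 100000 nM, a limit
Compound 3 `O=C(Nc1ccc(Sc2nc3ccccc3s2)cc1)c1cc(Br)cc(Br)c1O`: 66000 nM

In an ADME assay on HEK293 cells (Homo sapiens) for cytotoxicity, read by reporter gene assay and resazurin assay, with a stated time of 48 h (a lower number here means that less compound is tolerated, a higher number that more compound is tolerated), compound 1 gives 76000 nM, which lies within the scatter of compound 3. Compound 2 offers no number for comparison, only a limit.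

Compound 4 `O=C(Nc1ccc(Sc2nc3ccccc3s2)c(Cl)c1)c1ccccc1` departs from compound 1 at a single place: phenyl in place of 3,5-dibromo-2-hydroxyphenyl on a carbonyl carbon. In words, it carries phenyl in place of 3,5-dibromo-2-hydroxyphenyl on a carbonyl carbon.

Among the measured compounds shown here, the only measured step, a 1.2-fold lower number from compound 1 to compound 3 (0.06 log units; within the scatter), is hydrogen in place of chloro on an aromatic carbon, so it is a different change and says nothing directly about this one. For the measured compounds named here, it shows only that one change to compound 1 left the number within the scatter. Going by the values given here, with no measured step at this place, a large shift is not expected in this assay, though a slight upward drift would fit the limit seen for compound 2.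

The expected result is a 1.4-fold higher number from compound 1 to compound 4 (0.16 log units; within the scatter). For compound 4 the estimate is 110000 nM, with an expected range of 55000 nM to 220000 nM.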

Compound 4, half-maximal cytotoxic concentration: 90000 nM
Beside the measured number, compound 4's estimate is 1.2-fold (0.09 log units) above it, within the range that was stated.
By their numbers in this assay, from the lowest: compounds 3, 1 and 4 (each within the scatter of the next). At a limit, above all of these: compound 2.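

In this assay, phenyl in place of 3,5-dibromo-2-hydroxyphenyl on a carbonyl carbon gives a 1.2-fold higher number from compound 1 to compound 4 (0.07 log units; within the scatter). The earlier step had touched only the chloro group on an aromatic carbon, whereas this one shows that the group on the carbonyl carbon can also be changed without leaving the scatter, even with both bromines and the hydroxyl removed together. Compound 2 gives only a limit, which marks where readings stop in this assay: the limit of > 100000 nM in this assay, at which 1 of the 4 values shown sits.

The bromines and the hydroxyl left in a single step, so the compounds shown do not separate what each contributes on its own. From the compounds shown here alone, it also remains open whether an amine or a carboxylic acid on the phenyl, or a longer chain in its place, would move the number beyond the scatter.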